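The source may report more compounds than this note shows. Statements on the series, on what has been measured and on what is new or still open speak of the compounds shown alone.

In a functional assay on MCF7 cells (Homo sapiens) for antiproliferative activity, with a stated time of 5 days (a higher number here means a weaker inhibitor, a lower number a stronger inhibitor), compound 1 `CCCCc1ccc2[nH]c(-c3ccc(OC)cc3)c(/C=N/NC(=O)c3cccc(OC)c3)c2c1` has "not determined" (no result reported), compound 2 `CCCCc1ccc2[nH]c(-c3ccc(OC)cc3)c(/C=N/NC(=O)c3ccccc3OC)c2c1` gives 71 nM and compound 3 `CCCCc1ccc2[nH]c(-c3ccc(OC)cc3)c(/C=N/NC(=O)c3ccncc3)c2c1` gives 69 nM. Compound 3 therefore stands level with compound 2, within the scatter, and compound 1 offers no number for comparison. Compound 4 `CCCCc1ccc2[nH]c(-c3ccc(CC)cc3)c(/C=N/NC(=O)c3ccncc3)c2c1` carries ethyl in place of methoxy on an aromatic carbon. For the measured compounds named here, the one measured step, a 1.0-fold lower number from compound 2 to compound 3 (0.01 log units; within the scatter), is within the scatter, but it concerns pyridin-4-yl in place of 2-methoxyphenyl on a carbonyl carbon, so it bears only indirectly on this exchange. Going by the values given here, no measured step tests the methoxy group itself. In this assay, no change beyond the scatter is expected, with an estimated step of a 1.2-fold higher number from compound 3 to compound 4 (0.09 log units; within the scatter). For compound 4 the estimated value is 85 nM, with an expected range of 30 nM to 250 nM.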

Compound 4, half-maximal inhibitory concentration: 150 nM
The estimate for compound 4 lay 1.8-fold (0.25 log units) below the measured number; low and high end bracket the measured number.
By their numbers in this assay, from the lowest: compounds 3 and 2 (each within the scatter of the next); then compound 4.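

In this assay, for the compounds shown here, the exchange of 4-methoxyphenyl to 4-ethylphenyl gives a 2.2-fold higher number from compound 3 to compound 4 (0.34 log units; beyond the scatter) and is the first measured change at this position, a modest step beyond the scatter. The aromatic carbon para to a large group is therefore not indifferent to its substituent: ethyl loses some activity against methoxy but does not abolish it. No available measurement accounts for this step. Open, on these data alone, is whether a hydroxyl group, an amine or a longer chain such as propyl at this carbon would do better or worse. Also open, as far as these compounds go, is whether the same exchange behaves alike with 2-methoxyphenyl in place of pyridin-4-yl on the carbonyl carbon.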